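Swapping the Amine on the Thiocarbonyl Carbon

The source may hold more compounds than are shown below. What is called first, only, known or untested is meant among the compounds shown, and "the series" means these compounds.

Compound 1, `Cc1ccc2c(=O)c(CSC(=S)N(C(C)C)C(C)C)coc2c1`, gives 1400 nM in a functional assay on HeLa cells (Homo sapiens) for antiproliferative activity, read by MTT assay, with a stated time of 72 h; a higher number here means a weaker inhibitor, a lower number a stronger inhibitor.
Compound 2, `O=c1c(Cl)c(CSC(=S)N2CCOCC2)oc2ccccc12`, gives 4500 nM in this assay.
Compound 3, `CC(C)N(C(=S)SCc1oc2ccccc2c(=O)c1Cl)C(C)C`, gives > 40000 nM in this assay, which is a limit of the assay rather than a number.

Among the two actual numbers, compound 1 stands lowest; its nearest neighbour is compound 2, which sits beyond the scatter above it. Compound 3 sits at the limit of > 40000 nM in this assay, at which 1 of the 3 values shown sits.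

Compound 4, `Cc1ccc2c(=O)c(CSC(=S)N3CCOCC3)coc2c1`, has not yet been measured in this assay. It differs from compound 1 in one place:
morpholin-4-yl in place of diisopropylamino on a thiocarbonyl carbon

Among the compounds with values here, only one measured step bears on this exchange: an at least 8.8-fold higher number from compound 2 to compound 3 (0.94 log units; beyond the scatter). That step is the same swap run in the opposite direction, on a core that carries a different substituent, so it can only be carried over with caution. Read backwards, it points to a lower number when morpholin-4-yl replaces diisopropylamino, and compound 1 already holds the lowest number shown.

Compound 4 is therefore expected to give 400 nM in this assay, with a likely range from 100 nM to 1600 nM. That estimate means an expected step of a 3.5-fold lower number from compound 1 to compound 4 (0.54 log units; beyond the scatter).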

Compound 4, half-maximal inhibitory concentration: 6100 nM
Compound 4: the middle estimate sits 15-fold (1.18 log units) below what was measured; measured number outside the range, above it.
By their numbers in this assay, from the lowest: compound 1; then compounds 2 and 4 (each within the scatter of the next). At a limit, above all of these: compound 3.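

In this assay, placing morpholin-4-yl instead of diisopropylamino on the thiocarbonyl carbon gives a 4.4-fold higher number from compound 1 to compound 4 (0.64 log units; beyond the scatter), so on this core diisopropylamino is the group with the lower number. On the other core, compound 3, which carries diisopropylamino, gives > 40000 nM, a limit of the assay and not a number. The exchange therefore cannot be carried from one core to the other, since diisopropylamino gives the higher number on one and the lower number on the other, and the two steps point in opposite directions:  the same change on two cores in this assay, an at least 8.8-fold higher number (0.94 log units; beyond the scatter) from compound 2 to compound 3 and a 4.4-fold lower number (0.64 log units; beyond the scatter) from compound 4 to compound 1, at least 38-fold (1.58 log units) apart, beyond the scatter of two such steps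

The two cores differ in more than one place, so the compounds shown cannot tell which of those differences turns the effect of the exchange around. They also leave open how a different amine on the thiocarbonyl carbon, such as piperidin-1-yl or dimethylamino, would behave on either core, and whether its number would follow the pattern of compound 1 or that of compound 2.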